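Cyano in place of nitro: a cytotoxicity estimate

The compounds below may be only part of what the source reports. "The series", "measured", "known", "first", "only" and "open" are said of these compounds alone.

Measured so far in a functional assay on LNCaP cells (Homo sapiens) for cytotoxicity, read by sulforhodamine B assay, with a stated time of 72 h; a higher number here means a weaker inhibitor, a lower number a stronger inhibitor
Compound 1 `COc1cc(/C=C/C(=O)/C=C(O)/C=C/c2ccc(OC(C)(C)C(=O)Nc3ccc([N+](=O)[O-])c(C(F)(F)F)c3)c(OC)c2)ccc1O` gives > 100000 nM as a limit
Compound 2 `COc1ccc(/C=C/C(=O)/C=C(O)/C=C/c2ccc(OCC(C)(O)C(=O)Nc3ccc([N+](=O)[O-])c(C(F)(F)F)c3)c(OC)c2)cc1OC` gives 41800 nM

Among the compounds with values here, compound 2 holds the only true number, 41800 nM in this assay so far. Compound 1 is reported only as a limit, > 100000 nM in that assay.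

Within the data shown here, compound 3 `COc1ccc(/C=C/C(=O)/C=C(O)/C=C/c2ccc(OCC(C)(O)C(=O)Nc3ccc(C#N)c(C(F)(F)F)c3)c(OC)c2)cc1OC` carries cyano in place of nitro on an aromatic carbon, ortho to a trifluoromethyl group and para to a large group cyano in place of nitro on an aromatic carbon as its one difference from compound 2. Among the measured compounds shown here, no measured pair shows this change, so the expectation rests on compound 2 at 41800 nM alone. An estimated step of a 1.2-fold lower number from compound 2 to compound 3 (0.08 log units; within the scatter) is expected, with no change beyond the scatter. Compound 3 is estimated at 35000 nM (12000 nM to 100000 nM).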

Compound 3, half-maximal inhibitory concentration: 73000 nM
Compound 3: the middle estimate sits 2.1-fold (0.32 log units) below what was measured; the range from low to high includes it.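

Within the data shown here, with compound 3, the swap of nitro for cyano on this aromatic carbon can be read directly for the first time: in this assay it gives a 1.7-fold higher number from compound 2 to compound 3 (0.24 log units; within the scatter). At this position, ortho to a trifluoromethyl group and para to a large group, the two groups therefore cannot be told apart, and nitro is not needed for the activity of compound 2. Compound 1 remains a limit in the same assay: the limit of > 100000 nM in this assay, at which 1 of the 3 values shown sits.

Going by these compounds, whether an amine or a carboxylic acid at this carbon would move the number beyond the scatter remains open. So does whether cyano would behave the same way in compound 1.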